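A few compounds are considered here, and "the series" means these few. Any claim that something is new, unique, unknown or untested is made for them only; others in the source may bear on it.

Notes on the series, read in an ADME assay on HEK293 cells (Homo sapiens) for antiproliferative activity, read by MTT assay; on this read-out higher numbers stand for weaker inhibition and lower numbers for stronger inhibition: compound 1 (`CNC(=O)c1oc2nc(-c3ccccc3)cc(C(F)(F)F)c2c1N`) gives 62000 nM, compound 2 (`CNC(=O)c1oc2nc(-c3cccs3)cc(C(F)(F)F)c2c1N`) gives 75000 nM and compound 3 (`Cc1ccc(/C=N/NC(=O)c2oc3nc(-c4ccccc4)cc(C(F)(F)F)c3c2N)cc1`) gives 69000 nM. Compound 2 therefore stands within the scatter of both other compounds. Compound 4 (`CCCNC(=O)c1oc2nc(-c3cccs3)cc(C(F)(F)F)c2c1N`) differs from compound 2 by one change, (ethyl in place of hydrogen on a saturated chain carbon bound to an amide-type nitrogen), which reads methylcarbamoyl to propylcarbamoyl. The closest evidence is a 1.1-fold higher number from compound 1 to compound 3 (0.05 log units; within the scatter), a much larger replacement on the amide-type nitrogen that stayed within the scatter. The thiophen-2-yl swap, a 1.2-fold higher number from compound 1 to compound 2 (0.08 log units; within the scatter), also stayed within it. No shift beyond the scatter is therefore expected in this assay, in either direction. The expected change is a 1.1-fold lower number from compound 2 to compound 4 (0.04 log units; within the scatter). Compound 4 is estimated at 68000 nM, with an expected range of 35000 nM to 120000 nM.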

Compound 4, half-maximal inhibitory concentration: 64000 nM
For compound 4 the middle estimate is 1.1-fold (0.03 log units) above the measured one, within the range that was stated.
By their numbers in this assay, from the lowest: compounds 1, 4, 3 and 2 (each within the scatter of the next).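

In this assay, the change from methylcarbamoyl to propylcarbamoyl gives a 1.2-fold lower number from compound 2 to compound 4 (0.07 log units; within the scatter), so a plain alkyl extension at this position also produces no shift beyond the scatter. Unlike the earlier step on the amide-type nitrogen, this one was read with thiophen-2-yl in place of phenyl on the core. No available evidence explains this flat response.

Going by these compounds, it remains open whether a longer chain, or a chain ending in an amine or a carboxylic acid, would move the number beyond the scatter.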